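The source may report more compounds than this note shows. Statements on the series, on what has been measured and on what is new or still open speak of the compounds shown alone.

Compound 1 `CN(C)CCn1cnnc1-c1cc(Oc2ccc(NC(=O)N/N=C/c3ccc(Cl)cc3Cl)cc2F)ccn1` and compound 2 `CN(C)CCn1cnnc1-c1cc(Oc2ccc(NC(=O)N/N=C/c3ccc(F)cc3F)cc2F)ccn1` share one core and differ only in the ring attached to the carbon with a double bond to nitrogen. In a functional assay on MKN-45 cells (Homo sapiens) for cytotoxicity, read by MTT assay, with a stated time of 72 h (a higher number here means a weaker inhibitor, a lower number a stronger inhibitor), compound 1 gives 750 nM, and compound 2 gives 810 nM; the move between them is a 1.1-fold higher number from compound 1 to compound 2 (0.03 log units; within the scatter), so compound 2 stands with compound 1 inside the scatter and the two numbers cannot be separated. Compound 3 `CN(C)CCn1cnnc1-c1cc(Oc2ccc(NC(=O)N/N=C/c3ccc(O)cc3)cc2F)ccn1` carries 4-hydroxyphenyl in place of 2,4-difluorophenyl on a carbon with a double bond to nitrogen. Among the measured compounds shown here, the only measured step that bears on this place, a 1.1-fold higher number from compound 1 to compound 2 (0.03 log units; within the scatter), exchanged one pair of halogens for another and stayed within the scatter; no measured step removes both halogens or brings in a hydroxyl, so the data give no direct guide for this exchange. A modest weakening, somewhat beyond the scatter, is expected, a step of a 1.7-fold higher number from compound 2 to compound 3 (0.24 log units; within the scatter). Compound 3 is therefore estimated at 1400 nM in this assay, within a range of 450 nM to 4500 nM.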

Compound 3, half-maximal inhibitory concentration: 820 nM
The estimate for compound 3 lay 1.7-fold (0.23 log units) above the measured number; the measured number falls inside the stated range.
By their numbers in this assay, from the lowest: compounds 1, 2 and 3 (each within the scatter of the next).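

In this assay, the step of a 1.0-fold higher number from compound 2 to compound 3 (0.01 log units; within the scatter) and the step of a 1.1-fold higher number from compound 1 to compound 3 (0.04 log units; within the scatter) both stay inside the scatter, so 4-hydroxyphenyl on this carbon with a double bond to nitrogen cannot be separated from either halogenated ring. Among the compounds shown here, the earlier pair showed only one pair of halogens exchanged for another, whereas this result extends the same reading to a ring that has lost both halogens and gained a hydroxyl, counted as one hydrogen-bond donor and one hydrogen-bond acceptor. No supporting measurement is available to explain this result.

The three compounds leave open whether any group at this place gives a step beyond the scatter, such as a carboxylic acid or an amine on the ring. They also leave open how an unsubstituted phenyl or a 4-methoxyphenyl would compare with 4-hydroxyphenyl.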